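The source may report more compounds than this note shows. Statements on the series, on what has been measured and on what is new or still open speak of the compounds shown alone.

Within the data shown here, compound 2 `COc1cc(OCC(=O)Nc2cccc(NC(=O)c3ccc(N(C)C)cc3)c2)ccc1C=O` is the only member of this set with a numbered result: in an assay on isolated protein for inhibition of Rho-associated protein kinase 1 (Homo sapiens), read by scintillation counting, radiometric assay and 33P incorporation, with a stated time of 40 min, in the presence of a further agent that is not named here (on this read-out lower numbers stand for stronger inhibition and higher numbers for weaker inhibition), compound 2 gives 3740 nM. Compound 1 `CN(C)c1ccc(C(=O)Nc2cccc(NC(=O)COc3ccc4c(c3)NC(=O)CC4)c2)cc1` reaches only the limit of this assay, at > 10000 nM. Compound 3 `COc1ccc(OCC(=O)Nc2cccc(NC(=O)c3ccc(N(C)C)cc3)c2)cc1OC` likewise stops at the limit of this assay, at > 10000 nM. Two of the three results thus rest on (the limit of > 10000 nM in this assay, at which 2 of the 3 values shown sit). Compound 4 `CN(C)c1ccc(C(=O)Nc2cccc(NC(=O)COc3ccc4c(c3)OCCC4=O)c2)cc1` has not been measured; it differs from compound 2 by a group of 11 heavy atoms (9 carbon, 2 oxygen; one six-membered non-aromatic ring with 1 hetero atom, one six-membered aromatic ring of carbon only) in place of a group of 10 heavy atoms (8 carbon, 2 oxygen; one six-membered aromatic ring of carbon only), on an oxygen on a saturated carbon. Among the measured compounds shown here, the one measured step that bears on this change runs in the opposite direction: an at least 2.6-fold lower number from compound 1 to compound 2 (0.42 log units; beyond the scatter). Undoing a change of that kind is therefore expected to raise the number in this assay, at least modestly. Compound 4 is expected to give about 10000 nM, within 4000 nM to 30000 nM. The expected step is a 2.7-fold higher number from compound 2 to compound 4 (0.43 log units; beyond the scatter).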

Compound 4, half-maximal inhibitory concentration: 144 nM
The estimate for compound 4 lay 69-fold (1.84 log units) above the measured number, outside the stated range (below it).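

At the oxygen on a saturated carbon, a group with a six-membered non-aromatic ring can give much stronger inhibition in this assay, with a 26-fold lower number from compound 2 to compound 4 (1.41 log units; beyond the scatter) and an at least 69-fold lower number from compound 3 to compound 4 (1.84 log units; beyond the scatter). That ring alone does not settle the result: two groups of 11 heavy atoms, one with 1 nitrogen and 1 oxygen and the other with 2 oxygen, are separated by an at least 69-fold lower number from compound 1 to compound 4 (1.84 log units; beyond the scatter). Two of these steps start from a limit rather than a number: the limit of > 10000 nM in this assay, at which 2 of the 4 values shown sit.

The compounds shown leave open how an amine or a carboxylic acid on that ring would read. They also leave open whether a longer chain at this oxygen would keep the stronger inhibition.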